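A few compounds are considered here, and "the series" means these few. Any claim that something is new, unique, unknown or untested is made for them only; others in the source may bear on it.

Three compounds share a core that carries a trimethoxybenzyl group and an amino group, and differ in the chain on the aromatic nitrogen and in a fluorine. Compound 1 `CCC(CC)Cn1c(Cc2cc(OC)c(OC)c(OC)c2)nc2c(N)ncnc21` bears a 2-ethylbutyl chain, compound 2 `CCC(C)Cn1c(Cc2cc(OC)c(OC)c(OC)c2)nc2c(N)ncnc21` a 2-methylbutyl chain, and compound 3 `CCCn1c(Cc2cc(OC)c(OC)c(OC)c2)nc2c(N)nc(F)nc21` a propyl chain on a core that also holds a fluorine. In a functional assay on MCF7 cells (Homo sapiens) for antiproliferative activity (on this read-out higher numbers stand for weaker inhibition and lower numbers for stronger inhibition), compound 1 gives 158000 nM, compound 2 gives 61700 nM, and compound 3 gives 25100 nM, the lowest of the three numbers. Between compound 2 and compound 1 the single change methyl in place of hydrogen on a saturated chain carbon, three bonds along the chain from an aromatic nitrogen brought a 2.6-fold higher number from compound 2 to compound 1 (0.41 log units; beyond the scatter). How the cores of compound 2 and compound 3 differ is not broken down here.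

Compound 4 `CCCCn1c(Cc2cc(OC)c(OC)c(OC)c2)nc2c(N)nc(F)nc21` is not yet measured. It arises from compound 3 by methyl in place of hydrogen on a saturated chain carbon, three bonds along the chain from an aromatic nitrogen, the same change seen between compound 2 and compound 1, at the same place. Since that change gave a 2.6-fold higher number from compound 2 to compound 1 (0.41 log units; beyond the scatter), a step of similar size is expected from compound 3 to compound 4, namely a 2.2-fold higher number from compound 3 to compound 4 (0.34 log units; beyond the scatter). On that basis compound 4 is estimated at 55000 nM, with a range from 20000 nM to 150000 nM.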

Compound 4, half-maximal inhibitory concentration: 24000 nM
Estimate against measurement, compound 4: 2.3-fold (0.36 log units) above; the measured number falls inside the stated range.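

In this assay, the added methyl raised the number on the core of compound 2, but on the fluorine-bearing core it left no readable change: a 1.0-fold lower number from compound 3 to compound 4 (0.02 log units; within the scatter). The two results disagree by more than repeated measurements would explain, and the step seen on one core did not carry over at its earlier size to the other: the same change on two cores in this assay, a 2.6-fold higher number (0.41 log units; beyond the scatter) from compound 2 to compound 1 and a 1.0-fold lower number (0.02 log units; within the scatter) from compound 3 to compound 4, 2.7-fold (0.43 log units) apart, beyond the scatter of two such steps. This does not show why they differ, as the pairs differ both in the fluorine and in the chain, with 2-methylbutyl becoming 2-ethylbutyl in one pair and propyl becoming butyl in the other, and two pairs cannot separate these or predict the step on a further core.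

No pair shown holds one chain on the core both with and without the fluorine, and the separate roles of the fluorine and the chain shape remain open. Also open, on these data alone, is what a longer chain such as pentyl, or a chlorine in place of the fluorine, would do.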